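A few compounds are considered here, and "the series" means these few. Any claim that something is new, unique, unknown or untested is made for them only; others in the source may bear on it.

Of the compounds shown here, three have been measured in an in vitro functional assay on cells for antagonist activity at transient receptor potential cation channel subfamily V member 1 (Homo sapiens), read by reporter gene assay and calcium flux; a lower number here means a stronger inhibitor, a higher number a weaker inhibitor. Compound 1 `O=C(Nc1ccc(Cl)c(C(F)(F)F)c1)Nc1cccc2ccc(O)c(F)c12` gives 9.1 nM, compound 3 `O=C(Nc1ccc(Cl)c(C(F)(F)F)c1)Nc1cccc2cc[nH]c12` gives 67 nM, and compound 2 `NS(=O)(=O)Cc1ccccc1NC(=O)Nc1ccc(Cl)c(C(F)(F)F)c1` gives 460 nM. Compound 2 thus stands at the highest number of the three: compound 3 lies nearest, at a number lower by a step beyond the usual scatter, and compound 1 lies furthest, lower by a wider gap that is also beyond the scatter. Compound 4 `O=C(Nc1ccc(Cl)c(C(F)(F)F)c1)Nc1ccccc1CCCO` keeps the core of compound 2 and differs from compound 2 by 2-hydroxyethyl in place of sulfamoyl on a saturated chain carbon bound to an aromatic carbon. Among the measured compounds shown here, no measured pair shows this change, and the other two compounds carry cores of their own, so the effect of the change has no direct precedent in these numbers. Without a measured step of this kind, only a move of modest size in this assay is expected for compound 4, with the direction left open and a result within the scatter of compound 2 quite possible. For compound 4 the estimated value is 400 nM, with a range from 100 nM to 1600 nM. The step from compound 2 to compound 4 that this estimate implies is expected to be a 1.2-fold lower number from compound 2 to compound 4 (0.06 log units; within the scatter).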

Compound 4, half-maximal inhibitory concentration: 220 nM
Beside the measured number, compound 4's estimate is 1.8-fold (0.26 log units) above it; low and high end bracket the measured number.
By their numbers in this assay, from the lowest: compound 1; then compound 3; then compound 4; then compound 2.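

In this assay, among the compounds shown here, putting 2-hydroxyethyl in place of sulfamoyl on a saturated chain carbon bound to an aromatic carbon gives a 2.1-fold lower number from compound 2 to compound 4 (0.32 log units; beyond the scatter), the first measured step between two compounds that differ in one place, modest in size yet beyond the scatter. It shows that the sulfamoyl group is not needed at this position for activity in this assay: with 3-hydroxypropyl standing where sulfamoylmethyl stood, a chain with no sulfur or nitrogen in it keeps the activity, and the number goes down rather than up. No measurement on hand accounts for this step, and this single pair cannot tell which part of the exchange carries it.

The compounds shown leave open whether the hydroxyl matters at all, which a plain propyl chain would test, and whether an amine or a carboxylic acid at the end of the chain, or a longer chain, would move the number further. They also leave open whether the 3-hydroxypropyl chain would have any effect on the cores of compound 1 and compound 3.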